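The compounds below may be only part of what the source reports. "The series", "measured", "known", "first", "only" and "open" are said of these compounds alone.

In an assay on isolated protein for inhibition of 2-Hydroxyacid oxidase 2 (Homo sapiens), tested at 10 uM (on this read-out higher numbers stand for a stronger effect at the one concentration tested and lower numbers for a weaker effect), three compounds of a shared core have been measured. Compound 1 `Cc1n[nH]c(C(=O)O)c1Cc1ccc2ccccc2n1` gives 18%, compound 3 `Cc1n[nH]c(C(N)=O)c1Cc1cccc(-c2ccc(F)cc2)c1` gives 14%, and compound 2 `Cc1n[nH]c(C(=O)O)c1Cc1cccc(-c2ccc(OC(F)(F)F)cc2)c1` gives 34%, the highest of the three numbers, with its gaps to compound 1 and to compound 3 both beyond the scatter. Compound 4 `Cc1n[nH]c(C(=O)O)c1Cc1cccc(-c2ccc(C(N)=O)cc2)c1` is the next compound, differing from compound 2 by the change (carbamoyl in place of trifluoromethoxy on an aromatic carbon). Within the data shown here, no step between measured compounds speaks to this change, so the expectation for this assay rests only on compound 2 itself: a modest downward step, or none beyond the scatter, is anticipated. Compound 4 is expected to give 25%, within a range of 8% to 45%, which would mean a step of a number 9 percentage points lower from compound 2 to compound 4 (within the scatter) from compound 2 to compound 4.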

Compound 4, a percentage reported as inhibition, at one concentration (the size of the read-out at that concentration, not a potency): 60%
Beside the measured number, compound 4's estimate is 35 percentage points below it; the whole stated range lies below it.
By their numbers in this assay, from the lowest: compounds 3 and 1 (each within the scatter of the next); then compound 2; then compound 4.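

In this assay, among these compounds, carbamoyl in place of trifluoromethoxy gives a number 26 percentage points higher from compound 2 to compound 4 (beyond the scatter), the first step at this place on the aromatic carbon, para to a large group. Among the compounds shown here, it shows that the read-out answers to the group held there, which the earlier compounds, differing in more than one place, could not show. Nothing measured here accounts for the rise. Still open, as far as these compounds go, is whether a nitrile, an acetyl group or a sulfonamide on this carbon would behave like carbamoyl. So is whether the rise survives a methyl group on the amide nitrogen.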